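The source may hold more compounds than are shown below. What is called first, only, known or untested is meant among the compounds shown, and "the series" means these compounds.

Compound 1 `ClCc1ccccc1Cn1cnc2c(Cl)nc(Cl)nc21` and compound 3 `ClCc1ccc(Cn2cnc3nc(Cl)nc(Cl)c32)cc1` are built from the same atoms joined differently; the difference between their two cores is not broken down here. In a functional assay on SF-295 cells (Homo sapiens) for cytotoxicity, read by sulforhodamine B assay, with a stated time of 48 h (on this read-out higher numbers stand for weaker inhibition of growth and lower numbers for stronger inhibition of growth), compound 1 gives 3380 nM, and compound 3 gives 3310 nM, two numbers that lie within the scatter of each other, so nothing separates them.

Compound 2 `ClCc1ccccc1Cn1cnc2c(Cl)ncnc21` differs from compound 1 in one place: hydrogen in place of chloro on an aromatic carbon. In this assay compound 2 gives 23400 nM. This single change made a step of a 6.9-fold higher number from compound 1 to compound 2 (0.84 log units; beyond the scatter), which lies beyond the scatter and so counts as a real weakening of growth inhibition.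

Compound 4 `ClCc1ccc(Cn2cnc3ncnc(Cl)c32)cc1` stands to compound 3 as compound 2 stands to compound 1. The change is hydrogen in place of chloro on an aromatic carbon, and its place is described in the same words as the place of the change from compound 1 to compound 2, so it is the same change applied to the other core. Compound 4 has not yet been measured in this assay.

Within the data shown here, with only one earlier example of this change, the expectation rests on it alone. Because compound 1 gives 3380 nM and compound 3 gives 3310 nM, two readings within the scatter of each other, and because the step of a 6.9-fold higher number from compound 1 to compound 2 (0.84 log units; beyond the scatter) was clear, the step from compound 3 to compound 4 is expected to be about a 6.6-fold higher number from compound 3 to compound 4 (0.82 log units; beyond the scatter). Compound 4 is therefore estimated to give 22000 nM in this assay, most likely between 9000 nM and 55000 nM.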

Compound 4, concentration for total growth inhibition: 5010 nM
Beside the measured number, compound 4's estimate is 4.4-fold (0.64 log units) above it; the whole stated range lies above it.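

On the core of compound 3, putting hydrogen in place of chloro gives in this assay a 1.5-fold higher number from compound 3 to compound 4 (0.18 log units; within the scatter), so on this core the change leaves no detectable mark on growth inhibition. Among these compounds, the same change therefore does not carry over at the same size from one core to the other, even though compound 1 and compound 3 read alike before it is made: the same change on two cores in this assay, a 6.9-fold higher number (0.84 log units; beyond the scatter) from compound 1 to compound 2 and a 1.5-fold higher number (0.18 log units; within the scatter) from compound 3 to compound 4, 4.6-fold (0.66 log units) apart, beyond the scatter of two such steps What this does not show is why the two cores respond differently, and with only one pair on each core it sets no general rule, only a warning that a step seen on one core may not predict the step on a closely related one.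

The compounds shown leave open how a group other than chloro or hydrogen, such as an amine or a methoxy group, would behave on this aromatic carbon between two ring nitrogen atoms, and whether it too would give different steps on the two cores. They also leave open whether the difference between the two steps would appear in any other cell line.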